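The compounds below may be only part of what the source reports. "The series", "measured", "known", "first", "only" and "open" are said of these compounds alone.

Of the compounds shown here, two that share one core have so far been tested in a functional assay on Bel-7402 cells (Homo sapiens) for cytotoxicity, read by MTT assay; a higher number here means a weaker inhibitor, a lower number a stronger inhibitor. Compound 1 `CCn1cc(C(=O)Nc2ccc(Cl)cn2)c(=O)c2cc(F)c(N3CCNC(C)C3)c(F)c21` gives 4900 nM in this assay. Compound 2 `CCn1cc(C(=O)Nc2cc([N+](=O)[O-])ccc2F)c(=O)c2cc(F)c(N3CCNC(C)C3)c(F)c21` gives 2900 nM in this assay, the lowest of the two numbers shown, yet its gap to compound 1 is within the scatter, so the two cannot really be told apart. Compound 3 `CCn1cc(C(=O)NCc2ccc(OC)cc2)c(=O)c2cc(F)c(N3CCNC(C)C3)c(F)c21` is not yet measured. It differs from compound 2 in one place: 4-methoxybenzyl in place of 2-fluoro-5-nitrophenyl on an amide-type nitrogen.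

Going by the values given here, the only measured step, a 1.7-fold lower number from compound 1 to compound 2 (0.23 log units; within the scatter), also exchanged the group on the amide-type nitrogen, swapping one aromatic ring for another, and moved the number by less than the scatter. It bears on the present step only loosely, since 4-methoxybenzyl is a different kind of group from the aromatic ring that each of the two measured compounds carries on the amide-type nitrogen. Among the compounds with values here, with a single within-scatter step as the only guide, no change beyond the scatter is expected in this assay in either direction, the step of a 1.4-fold higher number from compound 2 to compound 3 (0.14 log units; within the scatter) being the estimated outcome. Compound 3 is therefore estimated at 4000 nM in this assay, with a range from 1500 nM to 12000 nM.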

Compound 3, half-maximal inhibitory concentration: 10300 nM
For compound 3 the middle estimate is 2.6-fold (0.41 log units) below the measured one; measured number inside the range.
By their numbers in this assay, from the lowest: compounds 2 and 1 (each within the scatter of the next); then compound 3.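

Putting 4-methoxybenzyl on the amide-type nitrogen in place of 2-fluoro-5-nitrophenyl gives a 3.6-fold higher number from compound 2 to compound 3 (0.55 log units; beyond the scatter) in this assay, and in place of 5-chloropyridin-2-yl it gives a 2.1-fold higher number from compound 1 to compound 3 (0.32 log units; beyond the scatter). Both steps are modest but beyond the scatter, so this position can shift the number after all, which the exchange between the two earlier groups did not show; among these three compounds, compound 3 is the weakest inhibitor. No measurement at hand offers a reason for this shift.

The compounds shown leave open whether the higher number goes with the methoxy group or with the benzyl part, as the two enter together in a single change; a plain benzyl group or a 4-methoxyphenyl group on the same nitrogen would separate them. They also leave open how this nitrogen would respond to a group with no aromatic ring at all, such as a longer carbon chain or a chain ending in a carboxylic acid or an amine.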